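Amide in place of amine on a diterpenoid lactone

The source may report more compounds than this note shows. Statements on the series, on what has been measured and on what is new or still open speak of the compounds shown alone.

Of the compounds shown here, two of the same core have been measured in a functional assay on BMMC cells (Mus musculus, strain C57BL/6) for inhibition, with stated times of 5 days and 48 h; on this read-out lower numbers stand for stronger inhibition and higher numbers for weaker inhibition. Compound 1, `C=C1CC[C@@H]2[C@](C)(CO)[C@H](O)CC[C@@]2(C)[C@@H]1C/C=C1\C=COC1=O`, which carries a hydroxymethyl group on the core, gives 2770 nM in this assay. Compound 2, `C=C1CC[C@@H]2[C@](C)(CNCc3cccc(OC)c3)[C@H](O)CC[C@@]2(C)[C@@H]1/C=C/C1=CCOC1=O`, gives 780 nM in this assay. Within the data shown here, compound 2 therefore stands at the lowest of the two numbers so far, and its nearest neighbour, compound 1, sits a step higher that lies beyond the usual scatter.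

The step considered next leads from compound 2 to compound 3, `C=C1CC[C@H]2[C@@](C)(CC[C@@H](O)[C@@]2(C)C(=O)NCc2ccc(Br)cc2)[C@@H]1/C=C/C1=CCOC1=O`, which has not yet been measured in this assay. The change is (4-bromobenzyl)carbamoyl in place of ((3-methoxybenzyl)amino)methyl on a saturated ring carbon. Both groups hold one six-membered aromatic ring of carbon only and one hydrogen-bond donor, while the entering group brings one hydrogen-bond acceptor rather than two and one double bond outside aromatic rings.

Among the measured compounds shown here, with only two measured compounds, and neither sharing this amide, the expectation for compound 3 rests on little. A modest weakening is expected, and the step of a 1.9-fold higher number from compound 2 to compound 3 (0.28 log units; within the scatter) is estimated to fall near the edge of the scatter. Compound 3 is thus expected to give about 1500 nM in this assay, within a range from 400 nM to 6000 nM.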

Compound 3, half-maximal inhibitory concentration: 3450 nM
Beside the measured number, compound 3's estimate is 2.3-fold (0.36 log units) below it; measured number inside the range.
By their numbers in this assay, from the lowest: compound 2; then compounds 1 and 3 (each within the scatter of the next).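

In this assay, among these compounds, placing (4-bromobenzyl)carbamoyl in place of ((3-methoxybenzyl)amino)methyl on this saturated ring carbon gives a 4.4-fold higher number from compound 2 to compound 3 (0.65 log units; beyond the scatter), the first step at this position that can be read. It shows that the read-out responds to the group held here, even though both groups hold a six-membered aromatic ring of carbon only and a hydrogen-bond donor, so keeping these features does not keep the lower number of compound 2. The change is nonetheless a composite one, since the amine becomes an amide while the 3-methoxy on the benzyl ring gives way to 4-bromo, and the single step cannot be divided among these differences. Nothing at hand accounts for the step.

Still open, from the compounds shown here alone, is which of these differences carries the step, a question that a (4-bromobenzyl)aminomethyl group or a (3-methoxybenzyl)carbamoyl group on the same carbon would separate. Also open, going by these compounds, is how a plain aminomethyl group or a carboxylic acid at this carbon, with no benzyl ring at all, would compare.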